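Triazole side chain: amide to plain alkyl in compound 4

The source may report more compounds than this note shows. Statements on the series, on what has been measured and on what is new or still open speak of the compounds shown alone.

Three compounds of the series share one boronic ester core and a benzyl-substituted triazole, and differ only in the group carried on the triazole's remaining aromatic carbon. Compound 1 `CC1(C)[C@@H]2C[C@H]3OB([C@H](CCCCN)NC(=O)Cn4nc(CCC(=O)O)nc4Cc4ccccc4)O[C@@]3(C)[C@H]1C2` gives 7.1 nM in an assay on isolated protein for inhibition of serine protease 1 (Homo sapiens); on this read-out lower numbers stand for stronger inhibition and higher numbers for weaker inhibition. Compound 2 `CC(C)(C)OC(=O)/C=C/c1nc(Cc2ccccc2)n(CC(=O)N[C@@H](CCCCN)B2O[C@@H]3C[C@@H]4C[C@@H](C4(C)C)[C@]3(C)O2)n1` gives 36 nM in this assay, and compound 3 `CC(C)C(=O)NCc1nc(Cc2ccccc2)n(CC(=O)N[C@@H](CCCCN)B2O[C@@H]3C[C@@H]4C[C@@H](C4(C)C)[C@]3(C)O2)n1` gives 9.6 nM in this assay. Compound 3 therefore sits second highest of the three numbers: its nearest neighbour is compound 1, a 1.4-fold higher number from compound 1 to compound 3 (0.13 log units; within the scatter), and its most distant is compound 2, a 3.8-fold lower number from compound 2 to compound 3 (0.57 log units; beyond the scatter). The change to compound 4 `CCCc1nc(Cc2ccccc2)n(CC(=O)N[C@@H](CCCCN)B2O[C@@H]3C[C@@H]4C[C@@H](C4(C)C)[C@]3(C)O2)n1` is ethyl in place of (isopropylcarbonyl)amino on a saturated chain carbon bound to an aromatic carbon. Within the data shown here, no measured step removes an amide from this side chain outright; the closest precedents are the exchange of carboxymethyl for the amide, a 1.4-fold higher number from compound 1 to compound 3 (0.13 log units; within the scatter), and the exchange of the ester-bearing ethenyl for the amide-bearing methyl, a 3.8-fold lower number from compound 2 to compound 3 (0.57 log units; beyond the scatter), which together show that two different polar substituents on this chain carbon give numbers close to each other while the bulkier ester arm gives a higher one. A plain propyl arm has no direct comparator here. On this basis the expected step is a small rise, a 1.7-fold higher number from compound 3 to compound 4 (0.22 log units; within the scatter), within or just at the edge of the scatter. Compound 4 is estimated at 16 nM in this assay, with a range from 5 nM to 50 nM.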

Compound 4, inhibition constant: 2.3 nM
The estimate for compound 4 lay 7.0-fold (0.84 log units) above the measured number, and the stated range ends above it.
By their numbers in this assay, from the lowest: compound 4; then compounds 1 and 3 (each within the scatter of the next); then compound 2.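

Every earlier arm at this position carried a carbonyl, yet replacing (isopropylcarbonyl)amino with ethyl on a saturated chain carbon bound to an aromatic carbon lowers the number in this assay (a 4.2-fold lower number from compound 3 to compound 4 (0.62 log units; beyond the scatter)), so this arm needs neither the amide nor any hydrogen-bond donor or acceptor to keep its inhibition. The plain propyl arm also improves on the acid-bearing arm, where methyl stands in place of carboxy (a 3.1-fold lower number from compound 1 to compound 4 (0.49 log units; beyond the scatter)), and on the ester-bearing ethenyl arm, by the largest step in the set (a 16-fold lower number from compound 2 to compound 4 (1.19 log units; beyond the scatter)), which leaves compound 4 the strongest of the four, with all three steps beyond the scatter. No measurement available here accounts for this order.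

With a single plain alkyl arm in the set, the chain length and the loss of the carbonyl cannot be told apart, and this one result does not establish a trend across alkyl groups. A butyl or ethyl arm in place of propyl would test the length, while a primary amine or a hydroxyl at the end of the propyl chain would show how far a single added polar atom is tolerated.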